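A few compounds are considered here, and "the series" means these few. Any claim that something is new, unique, unknown or untested is made for them only; others in the source may bear on it.

In an ADME assay on BJ cells (Homo sapiens) for cytotoxicity, with a stated time of 72 h (a lower number here means that less compound is needed, a higher number that more compound is needed for the effect), compound 1 (`C=C[C@@](C)(/C=C/c1ccc(O)c(/C=C/C#N)c1)CCC=C(C)C`) gives > 36600 nM as its reading, a limit and not a number. Compound 2 (`C=C[C@@](C)(/C=C/c1ccc(O)c(/C=C/c2ccc(F)cc2)c1)CCC=C(C)C`) gives > 36600 nM as its reading, also a limit. Compound 3 (`COc1ccc(/C=C/[C@@](C)(/C=C/c2ccc(O)c(/C=C/C#N)c2)CCC=C(C)C)cc1`) departs from compound 1 by 2-(4-methoxyphenyl)ethenyl in place of vinyl on a saturated chain carbon bound to a double-bonded chain carbon and two saturated chain carbons in one place: 2-(4-methoxyphenyl)ethenyl in place of vinyl on a saturated chain carbon bound to a double-bonded chain carbon and two saturated chain carbons. For the measured compounds named here, the only measured step is a step that the two limits leave unreadable from compound 1 to compound 2 and it concerns a different change, 4-fluorophenyl in place of cyano, so it offers neither a size nor a direction to carry over. In this assay no step beyond the scatter is therefore expected, and another limit is the likeliest reading. The estimated step is an at least 1.0-fold lower number from compound 1 to compound 3 (0.00 log units; that floor lies within the scatter) on this reckoning. Compound 3 is expected at 36000 nM with an estimated range from 15000 nM to 60000 nM in repeat measurements.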

Compound 3, half-maximal effective concentration: > 23700 nM
Compound 3: only a limit was reported (the forecaster's own chance of this, stated with the estimate: 75%); the middle value is on the limit's open side.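

In this assay compound 3 gives > 23700 nM, a limit and not a number. For the compounds shown here, compound 1 also reads only as a limit, so no step from compound 1 to compound 3 can be read. The compounds shown leave open what concentration produces the effect in this assay for any of them, and whether 2-(4-methoxyphenyl)ethenyl in place of vinyl changes it.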